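The source may hold more compounds than are shown below. What is called first, only, known or untested is meant among the compounds shown, and "the series" means these compounds.

Measured compounds in a functional assay on MGC-803 cells (Homo sapiens) for inhibition, read by MTT assay, with a stated time of 72 h; a higher number here means a weaker inhibitor, a lower number a stronger inhibitor:

compound 1, `O=C(CSc1nc(Nc2ccccc2)c2ccccc2n1)Nc1cccc([N+](=O)[O-])c1`, gives 28100 nM
compound 2, `O=C(CSc1nc(Nc2ccccc2)c2ccccc2n1)Nc1ccc(F)c(Cl)c1`, gives 20900 nM
compound 3, `C=CC(=O)Nc1cccc(NC(=O)CSc2nc(Nc3ccccc3F)c3ccccc3n2)c1`, gives 26100 nM

All three values of this assay sit within the usual scatter of one another. Compound 3 is nearest to compound 1 and somewhat further from compound 2, but neither gap exceeds the scatter, so no ranking among the three is supported. Among the compounds with values here, the only measured single-site step, a 1.3-fold lower number from compound 1 to compound 2 (0.13 log units; within the scatter), concerns the group on the amide-type nitrogen and is itself within the scatter.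

Compound 4, `C=CC(=O)Nc1cccc(NC(=O)CSc2nc(Nc3ccccc3C)c3ccccc3n2)c1`, has not been measured in this assay. It differs from compound 3 by methyl in place of fluoro on an aromatic carbon. Within the data shown here, no measured pair changes the anilino ring in this way; the one measured step sits elsewhere in the molecule and was small. With nothing in the data pointing to a change at this position, no step beyond the scatter is expected from compound 3 to compound 4 in this assay.

The value of compound 4 in this assay is therefore estimated at 26000 nM, with the range 9000 nM to 75000 nM. This estimate corresponds to an expected step of a 1.0-fold lower number from compound 3 to compound 4 (0.00 log units; within the scatter), within the scatter.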

Compound 4, half-maximal inhibitory concentration: 30200 nM
Estimate against measurement, compound 4: 1.2-fold (0.07 log units) below, and the stated range covers the measured number.
By their numbers in this assay, from the lowest: compounds 2, 3, 1 and 4 (each within the scatter of the next).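

Within the data shown here, the exchange of fluoro for methyl on an aromatic carbon, ortho to a large group, is the first single-site change on the anilino ring that can be read in this assay, and it comes out as a 1.2-fold higher number from compound 3 to compound 4 (0.06 log units; within the scatter). Fluoro and methyl at this position are therefore not told apart in this assay, and this change joins the one on the amide-type nitrogen, a 1.3-fold lower number from compound 1 to compound 2 (0.13 log units; within the scatter), as a second step at a different site that stays within the scatter. No available measurement bears on why this exchange leaves the number within the scatter.

As far as these compounds go, whether an amine, a carboxylic acid or a longer chain such as propyl on this aromatic carbon, in place of fluoro or methyl, would move the number beyond the scatter remains open. The compounds shown also include no pair that isolates the acrylamide group from the other groups on the amide-type nitrogen, so what that group contributes in this series cannot yet be read.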